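Swapping a furan ring for phenyl: expected cytotoxicity

The source may hold more compounds than are shown below. What is called first, only, known or untested is meant among the compounds shown, and "the series" means these compounds.

Of the compounds shown here, three sharing a common core have been tested in a functional assay on T47D cells (Homo sapiens) for cytotoxicity, read by CCK-8 assay and cell counting, with a stated time of 2 days; on this read-out higher numbers stand for weaker inhibition and lower numbers for stronger inhibition. Compound 1 `Oc1cccc(-c2cc(-c3ccccc3)nc(-c3ccc(Cl)cc3)c2)c1` gives 11300 nM, compound 2 `Oc1cccc(-c2cc(-c3ccc(Cl)cc3)nc(-c3ccco3)c2)c1` gives 10500 nM, and compound 3 `Oc1ccc(-c2cc(-c3cccc(Cl)c3)nc(-c3ccco3)c2)cc1` gives 5220 nM. The difference between the cores of compound 3 and compound 2 is not broken down here. Compound 1 differs from compound 2 by phenyl in place of furan-2-yl on an aromatic carbon, and this change made a 1.1-fold higher number from compound 2 to compound 1 (0.03 log units; within the scatter). Compound 4 `Oc1ccc(-c2cc(-c3ccccc3)nc(-c3cccc(Cl)c3)c2)cc1` has not yet been measured; it differs from compound 3 by phenyl in place of furan-2-yl on an aromatic carbon. This is the same kind of change, not the same one: in compound 4 the changed carbon is meta to a 3-chlorophenyl group and meta to a 4-hydroxyphenyl group, whereas in compound 1 it is meta to a 3-hydroxyphenyl group and meta to a 4-chlorophenyl group. Since the same kind of change gave a 1.1-fold higher number from compound 2 to compound 1 (0.03 log units; within the scatter), a similar small outcome is expected, a 1.1-fold higher number from compound 3 to compound 4 (0.05 log units; within the scatter). Compound 4 is therefore estimated at 5800 nM in this assay, most likely between 2600 nM and 13000 nM.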

Compound 4, half-maximal inhibitory concentration: 4790 nM
The estimate for compound 4 lay 1.2-fold (0.08 log units) above the measured number; measured number inside the range.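

In this assay, putting phenyl in place of furan-2-yl gave a 1.1-fold lower number from compound 3 to compound 4 (0.04 log units; within the scatter). The same change gave closely matching results on the two cores: the same change on two cores in this assay, a 1.1-fold higher number (0.03 log units; within the scatter) from compound 2 to compound 1 and a 1.1-fold lower number (0.04 log units; within the scatter) from compound 3 to compound 4, 1.2-fold (0.07 log units) apart, within the scatter of two such steps. This shows that, in these two pairs, the swap carries over from one core to the other and leaves the number essentially unchanged, but two pairs cannot show that it would do so on every core in the series, nor why the two rings give such similar results.

The compounds shown leave open what a group other than these two aromatic rings would do on this carbon. An amine or a carboxylic acid there, for example, might or might not change the number.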